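The compounds below may be only part of what the source reports. "The series", "measured", "known", "first", "only" and "open" are said of these compounds alone.

- Compound 1 `Cc1ccc(S(=O)(=O)N2CC(c3ccc(Br)cc3)NC2=O)cc1`: > 253000 nM, a limit of the assay
- Compound 2 `O=C1NC(c2ccc(Br)cc2)CN1S(=O)(=O)c1ccc(Cl)cc1`: 161000 nM

Among the measured compounds shown here, in a functional assay on A549 cells (Homo sapiens) for cytotoxicity (a higher number here means a weaker inhibitor, a lower number a stronger inhibitor), compound 2 gives 161000 nM, the only actual number so far. Compound 1, by contrast, is recorded only as a limit, > 253000 nM.

The next compound, compound 3 `O=C1NC(c2ccccc2)CN1S(=O)(=O)c1ccc(Cl)cc1`, changes compound 2 at one place: hydrogen in place of bromo on an aromatic carbon. For the measured compounds named here, the bromo group is replaced by hydrogen, and no measured step covers that exchange. Going by the values given here, the one measured step, an at least 1.5-fold lower number from compound 1 to compound 2 (0.19 log units; that floor lies within the scatter), concerns a different group, so it offers only indirect guidance. Going by that small step, no change beyond the scatter is expected in this assay, in either direction. The estimated 1.1-fold higher number from compound 2 to compound 3 (0.05 log units; within the scatter) is therefore small. For compound 3 the expected value is 180000 nM, with an estimated range from 80000 nM to 350000 nM.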

Compound 3, half-maximal inhibitory concentration: 9470 nM
Compound 3: middle estimate off by 19-fold (1.28 log units), on the high side; the whole stated range lies above it.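

Going from 4-bromophenyl to phenyl in this assay gives a 17-fold lower number from compound 2 to compound 3 (1.23 log units; beyond the scatter), so this place on the aromatic ring, para to a large group, strongly affects the read-out, and the unsubstituted phenyl is the stronger of the pair. The earlier step concerned the other aromatic ring and gave only a floor within the scatter, so it did not reveal a change of this size. That floor rests on compound 1, which is recorded only as a limit: the limit of > 253000 nM in this assay, at which 1 of the 3 values shown sits.

The compounds shown leave open whether bromo is unusual here or whether fluoro, methoxy or an amine at the same place would also give a higher number than hydrogen. They also leave open whether the exchange of methyl for chloro would act in the same way with the phenyl group in place.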